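Methoxy for methyl on the benzyl arm of compound 1

The source may hold more compounds than are shown below. What is called first, only, known or untested is meant among the compounds shown, and "the series" means these compounds.

Measured so far in a functional assay on KB cells (Homo sapiens) for cytotoxicity; on this read-out higher numbers stand for weaker inhibition and lower numbers for stronger inhibition:
compound 1 `Cc1ccc(Cn2cc(C#N)c3c(N)ncnc32)cc1`: > 100000 nM
compound 2 `NC(=S)c1cn(Cc2ccccc2)c2ncnc(N)c12`: 32000 nM
compound 3 `Cc1ccc(Cn2cc(C(=N)S)c3c(N)ncnc32)cc1`: 65000 nM

The value of compound 1 is a limit of this assay, not a number, and among the three values shown it is the one that sits at the limit of > 100000 nM in this assay, at which 1 of the 3 values shown sits. Going by the values given here, compound 2 gives 32000 nM and compound 3 gives 65000 nM; no step is computed for that pair, and the two numbers are all that can be said of them. Among the compounds with values here, the single computed step, an at least 1.5-fold lower number from compound 1 to compound 3 (0.18 log units; that floor lies within the scatter), replaces the nitrile with the thioamide on an aromatic carbon of the core and says nothing about the benzyl arm.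

Compound 4 `COc1ccc(Cn2cc(C#N)c3c(N)ncnc32)cc1` differs from compound 1 by methoxy in place of methyl on an aromatic carbon. Within the data shown here, no measured step exchanges these two groups, so no size and no direction can be taken from the measured compounds. With compound 1 at a limit, a shift of modest size in either direction would stay hidden, and a further limit is the expected outcome. Resting on the limit shown by compound 1, compound 4 is expected near 150000 nM, between 50000 nM and 500000 nM. The implied step, a step that the limit leaves unreadable from compound 1 to compound 4, is expected to stay within the scatter.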

Compound 4, half-maximal inhibitory concentration: > 100000 nM
Compound 4 gave a limit, no number; the forecaster's own chance of this, stated with the estimate: 70%; the middle value does not contradict the limit.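

In this assay compound 4 gives > 100000 nM, a limit and not a number. Going by these compounds alone, compound 1 gives > 100000 nM, also a limit, so no step between compound 1 and compound 4 can be read. The compounds shown leave open whether methoxy in place of methyl changes cytotoxicity at all.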